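Working notes: from compound 1 to compound 4 in Vero cytotoxicity

The compounds below may be only part of what the source reports. "The series", "measured", "known", "first", "only" and "open" are said of these compounds alone.

Compound 1 `CCOCCOC(=O)Nc1cc2nc(C3CCCCC3)[nH]c2cc1N1CCCC1` stands only at a limit on the numbers available. In an ADME assay on Vero cells (Chlorocebus sabaeus) for cytotoxicity, read by resazurin assay, with a stated time of 3 days (a lower number here means a stronger inhibitor, a higher number a weaker inhibitor), compound 1 gives > 100 ug/mL, a limit of the assay and not a number. Compound 2 `CCOCCOC(=O)Nc1cc2nc(C3CCCCC3)[nH]c2cc1N(CC)CC` and compound 3 `CCOCCOC(=O)Nc1cc2nc(C3CCCCC3)[nH]c2cc1N(C)C` share the core of compound 1 and differ from it only in the amine on an aromatic carbon. In this assay compound 2 gives > 100 ug/mL, again a limit. In this assay compound 3 gives > 100 ug/mL, also a limit. The steps among the three, a step that the two limits leave unreadable from compound 1 to compound 2, a step that the two limits leave unreadable from compound 1 to compound 3 and a step that the two limits leave unreadable from compound 2 to compound 3, therefore carry no readable size, and the limit of > 100 ug/mL in this assay, at which 3 of the 3 values shown sit, is the whole of the evidence so far. Compound 4 `CCCCCC(=O)Nc1cc2nc(C3CCCCC3)[nH]c2cc1N1CCCC1` has not yet been measured in this assay. Its difference from compound 1 is pentyl in place of 2-ethoxyethoxy on a carbonyl carbon. Going by the values given here, none of the measured steps touches the carbonyl carbon, so no step beyond the scatter can be read out in either direction. The expected step is a step that the limit leaves unreadable from compound 1 to compound 4. For compound 4 the estimate in this assay is 150 ug/mL, with a range from 50 ug/mL to 400 ug/mL, most likely reported again only as a limit.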

Compound 4, half-maximal inhibitory concentration: > 100 ug/mL
Compound 4 gave a limit, no number (the forecaster's own chance of this, stated with the estimate: 80%); the middle value lies beyond the limit too.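

In this assay, going by these compounds alone, compound 4 gives > 100 ug/mL, a limit of the assay and not a number, so no step between compound 1 and compound 4 can be read. The compounds shown leave open what cytotoxic concentration any of them has, and whether either changed group affects it: the limit of > 100 ug/mL in this assay, at which 4 of the 4 values shown sit.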